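Working notes on the series: compounds 1 to 3

The source may hold more compounds than are shown below. What is called first, only, known or untested is meant among the compounds shown, and "the series" means these compounds.

Measured so far:
- Compound 1, `Cc1nc(Cn2nc3ccc(-c4ccc(OC(F)(F)F)cc4)cn3c2=O)no1`; in an ADME assay on microsomes (Homo sapiens) for metabolic stability (a lower number here means that the compound disappears faster, a higher number that the compound lasts longer), compound 1 gives 6.58 h.
- Compound 2, `O=c1[nH]nc2ccc(-c3ccc(Oc4ccc(F)cc4)cc3)cn12`; in this assay compound 2 gives 6.58 h.

Going by the values given here, compound 2 stands level with compound 1 at the digits given; the two values lie within the scatter of each other, and no step between them is drawn, since the two structures differ in more than one place.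

Compound 3, `Cc1nc(Cn2nc3ccc(-c4ccc(Oc5ccc(F)cc5)cc4)cn3c2=O)no1`, is not yet measured in this assay. It differs from compound 2 in one place: (5-methyl-1,2,4-oxadiazol-3-yl)methyl in place of hydrogen on an aromatic nitrogen. Compound 1 carries this same group on the same aromatic nitrogen and gives 6.58 h, and compound 2 without it gives 6.58 h, so the change itself shows no sign of moving the read-out. The step of a 1.1-fold lower number from compound 2 to compound 3 (0.04 log units; within the scatter) is therefore expected to stay within the scatter, with no clear direction. Compound 3 is estimated at 6 h, with a range from 3 h to 10 h.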

Compound 3, half-life: 3.45 h
For compound 3 the middle estimate is 1.7-fold (0.24 log units) above the measured one; the range from low to high includes it.
By their numbers in this assay, from the lowest: compounds 3, 1 and 2 (each within the scatter of the next).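

In this assay, (5-methyl-1,2,4-oxadiazol-3-yl)methyl in place of hydrogen on an aromatic nitrogen gives a 1.9-fold lower number from compound 2 to compound 3 (0.28 log units; within the scatter), so this first direct reading of the change at this position shows no step beyond the scatter. With that group kept on the nitrogen, 4-fluorophenyl in place of trifluoromethyl on an oxygen on an aromatic ring gives a 1.9-fold lower number from compound 1 to compound 3 (0.28 log units; within the scatter), so this change also stays within the scatter. Nothing at hand bears on the reason for either step.

From the compounds shown here alone, whether an amine or a carboxylic acid on a longer chain at this aromatic nitrogen would give a step beyond the scatter stays open. Also open, going by these compounds, is whether the step on the nitrogen holds with trifluoromethyl on the oxygen.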